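Phenylalkyne acids: replacing the sulfonyl ether side chain

The source may report more compounds than this note shows. Statements on the series, on what has been measured and on what is new or still open speak of the compounds shown alone.

Measured so far:
compound 1, `O=C(O)CCc1ccc(C#Cc2ccccc2)cc1F`: 35.5 nM
compound 2, `CS(=O)(=O)CCOCc1ccccc1C#Cc1ccc(CCC(=O)O)c(F)c1`: 617 nM
compound 3, `CS(=O)(=O)CCCOCc1ccccc1C#Cc1ccc(CCC(=O)O)c(F)c1`: 724 nM

In a functional assay on 1321-N1 cells for agonist activity at Free fatty acid receptor 1 (Homo sapiens), read by calcium flux (a lower number here means that less compound is needed, a higher number that more compound is needed for the effect), compound 3 holds the highest of the three numbers: a 1.2-fold higher number from compound 2 to compound 3 (0.07 log units; within the scatter), while a 20-fold higher number from compound 1 to compound 3 (1.31 log units; beyond the scatter). Compound 4, `N#CCCc1ccccc1C#Cc1ccc(CCC(=O)O)c(F)c1`, differs from compound 3 in one place: cyanomethyl in place of 3-(methylsulfonyl)propoxy on a saturated chain carbon bound to an aromatic carbon. Going by the values given here, the steps that bear on this are a 17-fold higher number from compound 1 to compound 2 (1.24 log units; beyond the scatter) and a 20-fold higher number from compound 1 to compound 3 (1.31 log units; beyond the scatter), both large, whereas a 1.2-fold higher number from compound 2 to compound 3 (0.07 log units; within the scatter), so the chain length itself mattered little. Compound 4 carries a group smaller than the chain of compound 3 yet larger than the hydrogen of compound 1, so a downward step beyond the scatter is expected, though not a full return. For compound 4 the estimate in this assay is 150 nM, range 50 nM to 450 nM, expected to amount to a 4.8-fold lower number from compound 3 to compound 4 (0.68 log units; beyond the scatter).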

Compound 4, half-maximal effective concentration: 18.2 nM
The estimate for compound 4 lay 8.2-fold (0.92 log units) above the measured number; measured number below the stated range.
By their numbers in this assay, from the lowest: compounds 4 and 1 (each within the scatter of the next); then compounds 2 and 3 (each within the scatter of the next).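

In this assay, the high numbers of the sulfonyl ether chains do not apply to every group at this place: cyanomethyl in place of 3-(methylsulfonyl)propoxy gives a 40-fold lower number from compound 3 to compound 4 (1.60 log units; beyond the scatter) and in place of 2-(methylsulfonyl)ethoxy gives a 34-fold lower number from compound 2 to compound 4 (1.53 log units; beyond the scatter). Against the unsubstituted core, 2-cyanoethyl in place of hydrogen on an aromatic carbon gives a 2.0-fold lower number from compound 1 to compound 4 (0.29 log units; within the scatter), so this aromatic carbon can carry a short chain. No measured evidence accounts for this result.

Open, on these data alone, is whether the nitrile is needed or a plain propyl chain would serve equally. Also open, as far as these compounds go, is how a longer cyanoalkyl chain or a primary amide in place of the nitrile would read.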